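This account rests on a few compounds, and the source may have more. Where it says the series, first, only, none or still open, it means among the compounds named here.

Working notes on the series.

Compound 1 `CC(=O)c1ccc(NC(=O)C(CC(C)C)N(C(=O)c2ccccc2)S(=O)(=O)c2ccc(C)cc2)cc1` is the reference of the set. In a functional assay for inhibition, read by spectrophotometry, with a stated time of 20 min, tested at 1 mg/mL (on this read-out higher numbers stand for a stronger effect at the one concentration tested and lower numbers for a weaker effect), compound 1 gives 54%. Compound 2 `CCC(C)C(C(=O)Nc1ccc(C(C)=O)cc1)N(C(=O)c1ccccc1)S(=O)(=O)c1ccc(C)cc1` carries one change against compound 1, namely (sec-butyl in place of isobutyl on a saturated chain carbon bound to an amide-type nitrogen and a carbonyl carbon), and in this assay compound 2 gives 18.6%; the step of a number 35.4 percentage points lower from compound 1 to compound 2 (beyond the scatter) is the largest movement seen among the measured compounds. Compound 3 `CC(=O)c1ccc(NC(=O)C(CC(C)C)N(C(=O)c2ccccc2)S(=O)(=O)c2ccccc2)cc1` differs from compound 1 by hydrogen in place of methyl on an aromatic carbon, and in this assay compound 3 gives 27.7%, with the step of a number 26.3 percentage points lower from compound 1 to compound 3 (beyond the scatter). The values of compound 3 and compound 2 lie within the scatter of each other, so no order between them is claimed.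

Compound 4 `CCC(C)C(C(=O)Nc1ccc(C(C)=O)cc1)N(C(=O)c1ccccc1)S(=O)(=O)c1ccccc1` is not yet measured. Against compound 3 it carries sec-butyl in place of isobutyl on a saturated chain carbon bound to an amide-type nitrogen and a carbonyl carbon, which is the same change as the one from compound 1 to compound 2, made at the same place; the two cores differ by hydrogen in place of methyl on an aromatic carbon. For the measured compounds named here, with only one earlier instance of the change, the expectation is that the step from compound 3 to compound 4 is downward, as in a number 35.4 percentage points lower from compound 1 to compound 2 (beyond the scatter), but smaller in size, because compound 3 starts from 27.7% and the read-out cannot fall below zero inhibition. The step is expected to be about a number 19.7 percentage points lower from compound 3 to compound 4 (beyond the scatter). For compound 4 in this assay the estimated value is 8%, with a plausible range from 0% to 25%, and this estimate rests on one precedent alone.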

Compound 4, a percentage reported as inhibition, at one concentration (the size of the read-out at that concentration, not a potency): 9.71%
Estimate against measurement, compound 4: 1.7 percentage points below, within the range that was stated.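

In this assay, sec-butyl in place of isobutyl keeps its downward direction on the second core, with a number 18 percentage points lower from compound 3 to compound 4 (beyond the scatter), but the size of the step does not carry over: the same change on two cores in this assay, a number 35.4 percentage points lower (beyond the scatter) from compound 1 to compound 2 and a number 18 percentage points lower (beyond the scatter) from compound 3 to compound 4, 17.4 percentage points apart, beyond the scatter of two such steps.
Hydrogen in place of methyl on an aromatic carbon also differs in size between the two cores, giving a number 8.9 percentage points lower from compound 2 to compound 4 (within the scatter), so no order is claimed between compound 2 and compound 4: the same change on two cores in this assay, a number 26.3 percentage points lower (beyond the scatter) from compound 1 to compound 3 and a number 8.9 percentage points lower (within the scatter) from compound 2 to compound 4, 17.4 percentage points apart, beyond the scatter of two such steps.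
These four compounds show that the effects of the two changes do not simply add on this read-out, but they do not show why, and with one pair of cores and one tested concentration they do not show how either change would behave on any other core or what it would do to potency.

The compounds shown leave open how a longer chain, a cyclohexyl or a benzyl group would read in place of isobutyl on the saturated chain carbon bound to the amide-type nitrogen and the carbonyl carbon. They also leave open whether a methoxy group, a chlorine or a carboxylic acid in place of the methyl on the aromatic carbon would go with the higher or the lower values of the series.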